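Inverting One Hydroxyl Centre on a Macrolide Cytotoxin

The source may report more compounds than this note shows. Statements on the series, on what has been measured and on what is new or still open speak of the compounds shown alone.

Measured so far:
compound 1, `CCCCC/C=C\C[C@@H](O)[C@H](O)/C=C/[C@@H]1C/C=C\CCCC(=O)O1`, gives 17.5 ug/mL in a functional assay on A549 cells (Homo sapiens) for cytotoxicity; on this read-out lower numbers stand for an effect already at smaller amounts and higher numbers for an effect only at larger amounts of compound
compound 2, `CC/C=C\C/C=C\C[C@@H](O)[C@H](O)/C=C/[C@@H]1C/C=C\CCCC(=O)O1`, gives 4.7 ug/mL in this assay

Going by the values given here, compound 2 stands lowest of the two numbers in this assay; the only measured step is a 3.7-fold lower number from compound 1 to compound 2 (0.57 log units; beyond the scatter), a change of a chain substituent. Compound 3, `CC/C=C\C/C=C\C[C@H](O)[C@H](O)/C=C/[C@@H]1C/C=C\CCCC(=O)O1`, differs from compound 2 only in this way: the two compounds have the same atoms and bonds and differ only in configuration as drawn: 1 of 7 stereo elements differ; a stereocentre at a saturated chain carbon is drawn R in compound 2 and S in compound 3. Among the compounds with values here, no measured step concerns a change of configuration, so nothing recorded bears directly on this inversion. One therefore expects no step beyond the scatter in this assay, while allowing wide uncertainty. Compound 3 is estimated at 6.5 ug/mL, with a range from 2.5 ug/mL to 20 ug/mL. That estimate means a 1.4-fold higher number from compound 2 to compound 3 (0.14 log units; within the scatter).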

Compound 3, concentration for half-maximal effect: 5.6 ug/mL
The estimate for compound 3 lay 1.2-fold (0.06 log units) above the measured number; the measured number falls inside the stated range.
By their numbers in this assay, from the lowest: compounds 2 and 3 (each within the scatter of the next); then compound 1.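

In this assay the inversion gives a 1.2-fold higher number from compound 2 to compound 3 (0.08 log units; within the scatter), so the number does not measurably depend on how this stereocentre at a saturated chain carbon is drawn. The earlier step concerned only a chain substituent, whereas here any difference could come only from this centre, because nothing else changes: the fact that compounds 2 and 3 differ only in the configuration as drawn

On these data alone, it remains open whether the same inversion would leave the number unchanged with the butyl chain of compound 1. As far as these compounds go, it is also open whether an amine or a methyl ether at this carbon would do so.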